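Alkoxy for azocane on the benzylic amide ring

The compounds below may be only part of what the source reports. "The series", "measured", "known", "first", "only" and "open" are said of these compounds alone.

Measured so far:
compound 1 `CC(C(=O)NCc1ccc(C(F)(F)F)cc1N1CCCCCCC1)c1ccc(NS(C)(=O)=O)c(F)c1` gives 2.8 nM
compound 2 `CCCCCCOc1cc(C(C)(F)F)ccc1CNC(=O)C(C)c1ccc(NS(C)(=O)=O)c(F)c1` gives 0.8 nM

In an assay on CHO cells for antagonist activity at transient receptor potential cation channel subfamily V member 1 (Homo sapiens), read by FLIPR (on this read-out lower numbers stand for stronger inhibition and higher numbers for weaker inhibition), compound 1 holds the highest of the two numbers, and compound 2 sits a step beyond the scatter lower. Compound 3 `CC(C)COc1cc(C(F)(F)F)ccc1CNC(=O)C(C)c1ccc(NS(C)(=O)=O)c(F)c1` is made from compound 1 by the change (a group of 5 heavy atoms (4 carbon, 1 oxygen; no ring) in place of a group of 8 heavy atoms (7 carbon, 1 nitrogen; one eight-membered non-aromatic ring with 1 hetero atom), on an aromatic carbon), a group of 5 heavy atoms (4 carbon, 1 oxygen; no ring) in place of a group of 8 heavy atoms (7 carbon, 1 nitrogen; one eight-membered non-aromatic ring with 1 hetero atom), on an aromatic carbon. Among the measured compounds shown here, with compound 2 as the only guide to an alkoxy group in this place, the step of a 1.8-fold lower number from compound 1 to compound 3 (0.24 log units; within the scatter) is expected to be small and downward, near the scatter. Compound 3 is estimated at 1.6 nM, within 0.5 nM to 5 nM.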

Compound 3, inhibition constant: 0.8 nM
For compound 3 the middle estimate is 2.0-fold (0.30 log units) above the measured one; low and high end bracket the measured number.
By their numbers in this assay, from the lowest: compounds 2 and 3 (each within the scatter of the next); then compound 1.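

Putting isobutoxy in place of the eight-membered non-aromatic ring gives, in this assay, a 3.5-fold lower number from compound 1 to compound 3 (0.54 log units; beyond the scatter) with the trifluoromethyl group and the rest of the core unchanged. This position therefore accepts an open chain joined through oxygen, with fewer heavy atoms and no ring, and the gain is modest but beyond the scatter. No measurement shown accounts for this step. The compounds shown leave open how a methoxy group or an unbranched butoxy chain would compare with isobutoxy here. They also leave open whether a piperidine ring would behave like the larger ring of compound 1.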